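Methoxycarbonyl on the outer ring of compound 2

A few compounds are considered here, and "the series" means these few. Any claim that something is new, unique, unknown or untested is made for them only; others in the source may bear on it.

Compounds measured so far, with their values in an assay on HEK293 cells for displacement of a labelled ligand from C-X-C chemokine receptor type 3 (Homo sapiens); a higher number here means a weaker inhibitor, a lower number a stronger inhibitor:
- compound 1, `CN(CC1=CC[C@H]2C[C@@H]1C2(C)C)Cc1ccc(F)cc1`: 6310 nM
- compound 2, `CN(CC1=CC[C@H]2C[C@@H]1C2(C)C)Cc1ccc(-c2ccccc2)cc1`: 3160 nM
- compound 3, `CN(CC1=CC[C@H]2C[C@@H]1C2(C)C)Cc1ccc(-c2ccc(C(F)(F)F)cc2)cc1`: > 316 nM (a limit of this assay, not a number)

All three share one core and differ only in the group on the benzylic ring. Compound 2 holds the lowest of the two numbers measured; its nearest neighbour is compound 1, and the step of a 2.0-fold lower number from compound 1 to compound 2 (0.30 log units; within the scatter) brings phenyl in place of fluoro. For compound 3 this assay reports only a limit, so the step that the limit leaves unreadable from compound 2 to compound 3 cannot be sized; the reason is the limit of > 316 nM in this assay, at which 1 of the 3 values shown sits.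

Compound 4, `COC(=O)c1cccc(-c2ccc(CN(C)CC3=CC[C@H]4C[C@@H]3C4(C)C)cc2)c1`, has not been measured. It differs from compound 2 as follows: methoxycarbonyl in place of hydrogen on an aromatic carbon. Within the data shown here, the only measured step that also adds a group to the outer ring is the one from compound 2 to compound 3, and its size is hidden by the limit; the step from compound 1 to compound 2 is a different kind of change and stayed within the scatter. Among the measured compounds shown here, no measured step therefore points to a change beyond the scatter.

Compound 4 is expected to give 2500 nM, with a range from 600 nM to 10000 nM. The estimated step of a 1.3-fold lower number from compound 2 to compound 4 (0.10 log units; within the scatter) is thus expected to be small.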

Compound 4, inhibition constant: > 316 nM
Compound 4 was reported as a limit; the forecaster's own chance of this, stated with the estimate: 30%; the middle value lies beyond the limit too.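

For compound 4, this assay gives only a limit, > 316 nM, so no size can be read for the change from compound 2 to compound 4, and the reason is this: the limit of > 316 nM in this assay, at which 2 of the 4 values shown sit.

On these data alone, whether methoxycarbonyl or trifluoromethyl on the outer ring moves the number of compound 2, in either direction, stays open.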